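Replacing a Chlorophenoxy Tail with Piperidine

This account rests on a few compounds, and the source may have more. Where it says the series, first, only, none or still open, it means among the compounds named here.

Measured in a functional assay on PC-3 cells (Homo sapiens) for cytotoxicity, read by MTT assay, with a stated time of 48 h; a lower number here means a stronger inhibitor, a higher number a weaker inhibitor:
compound 1 `CC1=NN(C(=O)COc2ccc(Cl)cc2)C(c2ccccc2O)C1` gives 38800 nM
compound 2 `CC1=NN(C(=O)COc2ccc(Cl)cc2)C(c2cc(Br)ccc2O)C1` gives 49000 nM
compound 3 `CC1=NN(C(=O)c2ccc(C)cc2)C(c2cc(Br)cc(Br)c2O)C1` gives 41200 nM

Among these three, compound 1 shows the lowest number, but the gaps to compound 2 and compound 3 are small: the step of a 1.3-fold higher number from compound 1 to compound 2 (0.10 log units; within the scatter), and the value of compound 3 sits even closer to that of compound 1. In practice the three compounds look alike in this assay.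

Compound 4 `CC1=NN(C(=O)CN2CCCCC2)C(c2ccccc2O)C1` has not yet been measured. Compared with compound 1, the change is piperidin-1-yl in place of 4-chlorophenoxy on a saturated chain carbon bound to a carbonyl carbon. Going by the values given here, none of the measured steps touches this part of the molecule; the only single-point step known here changes a substituent on an aromatic ring, and that step stayed within the scatter. There is therefore no measured basis for expecting a shift in either direction, and the estimate for compound 4 is kept close to the value of compound 1, with a wide range to reflect the lack of comparable data. Compound 4 is expected to give about 40000 nM, within 10000 nM to 150000 nM, which amounts to an expected step of a 1.0-fold higher number from compound 1 to compound 4 (0.01 log units; within the scatter).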

Compound 4, half-maximal inhibitory concentration: 5890 nM
Estimate against measurement, compound 4: 6.8-fold (0.83 log units) above, and the stated range ends above it.
By their numbers in this assay, from the lowest: compound 4; then compounds 1, 3 and 2 (each within the scatter of the next).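

In this assay, going by these compounds alone, placing piperidin-1-yl instead of 4-chlorophenoxy on the saturated chain carbon bound to a carbonyl carbon gives a 6.6-fold lower number from compound 1 to compound 4 (0.82 log units; beyond the scatter) and is the only single-place step here that lies beyond the scatter. Within the data shown here, the earlier bromo step on the aromatic ring stayed within the scatter, so this chain position is the first place where a change visibly moves the number. The swap replaces an aromatic carbon ring, its oxygen and its chlorine with a non-aromatic ring holding one nitrogen, and nothing shown gives a measured reason for the drop.

The compounds shown cannot separate these parts of the change, which a morpholine ring, an open-chain diethylamino group or an unsubstituted phenoxy group at the same position could help to do. On these data alone, it also remains open whether piperidin-1-yl has a similar effect when a bromo group sits on the aromatic ring, as in compound 2.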